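From a cyclohexyl ring to an isobutyl group

The source may hold more compounds than are shown below. What is called first, only, known or untested is meant among the compounds shown, and "the series" means these compounds.

Measured so far in a physicochemical assay for solubility, in phosphate buffer, with a stated time of 18 h; on this read-out lower numbers stand for lower solubility and higher numbers for higher solubility
- compound 1 `N#Cc1c(N)nc2nc(C3CC3)ncc2c1N` gives 23000 nM
- compound 2 `N#Cc1c(N)nc2nc(C3CCCC3)ncc2c1N` gives 89000 nM
- compound 3 `N#Cc1c(N)nc2nc(C3CCCCC3)ncc2c1N` gives 81000 nM

Compound 3 belongs to the upper pair of these three values. The gap within that pair is small: a 1.1-fold lower number from compound 2 to compound 3 (0.04 log units; within the scatter). The gap to the remaining value is larger: a 3.5-fold higher number from compound 1 to compound 3 (0.55 log units; beyond the scatter).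

Compound 4 `CC(C)Cc1ncc2c(N)c(C#N)c(N)nc2n1` has not yet been measured in this assay. It carries isobutyl in place of cyclohexyl on an aromatic carbon.

The three measured steps all exchange one ring for another at this same place, so they offer the nearest guidance. Besides the two above, there is a 3.9-fold higher number from compound 1 to compound 2 (0.59 log units; beyond the scatter). Within the data shown here, none of the measured compounds has a group without a ring there, so this guidance is loose. A small drop is expected, with no step beyond the scatter. The expected change is a 1.4-fold lower number from compound 3 to compound 4 (0.15 log units; within the scatter). For compound 4 the estimated value is 58000 nM, with an expected range from 25000 nM to 120000 nM.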

Compound 4, solubility: 268000 nM
For compound 4 the middle estimate is 4.6-fold (0.66 log units) below the measured one, outside the stated range (above it).
By their numbers in this assay, from the lowest: compound 1; then compounds 3 and 2 (each within the scatter of the next); then compound 4.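

Among these compounds, with isobutyl, the first group without a ring at this position, the number in this assay rises above all three rings (a 3.3-fold higher number from compound 3 to compound 4 (0.52 log units; beyond the scatter)) and (a 3.0-fold higher number from compound 2 to compound 4 (0.48 log units; beyond the scatter)) and (a 12-fold higher number from compound 1 to compound 4 (1.07 log units; beyond the scatter)). Among the rings, the change from cyclopentyl to cyclohexyl stayed within the scatter (a 1.1-fold lower number from compound 2 to compound 3 (0.04 log units; within the scatter)), whereas removing the ring altogether gave a step beyond the scatter against each of them, so these compounds show that the choice between a ring and an open chain at this position can matter more than the last ring swap did. Nothing available here explains the higher number for the open chain.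

A single branched chain cannot show whether open chains in general behave this way. A straight butyl chain, a longer chain or a chain carrying an amine could each follow isobutyl or fall back among the rings.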